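Working notes: from compound 3 to compound 4

A few compounds are considered here, and "the series" means these few. Any claim that something is new, unique, unknown or untested is made for them only; others in the source may bear on it.

- compound 1 `O=C(/C=C/c1cccc(OCc2ccccc2)c1)c1ccc([N+](=O)[O-])cc1` gives 17500 nM
- compound 2 `O=C(/C=C/c1cccc(OCc2ccccc2)c1)c1ccc(Cl)cc1Cl` gives 9400 nM
- compound 3 `O=C(/C=C/c1cccc(OCc2ccccc2)c1)c1ccc(Cl)cc1` gives 24800 nM

In a functional assay on MCF7 cells (Homo sapiens) for cytotoxicity, read by MTT assay, with a stated time of 68 h (a higher number here means a weaker inhibitor, a lower number a stronger inhibitor), compound 3 sits within the scatter of compound 1 and has a higher number than compound 2. Compound 4 `O=C(/C=C/c1cccc(OCc2ccccc2)c1)c1ccccc1Br` is not yet measured and carries the change 2-bromophenyl in place of 4-chlorophenyl on a carbonyl carbon with 2-bromophenyl in place of 4-chlorophenyl on a carbonyl carbon. The closest guide is a 2.6-fold higher number from compound 2 to compound 3 (0.42 log units; beyond the scatter) on losing a chloro, modest and beyond the scatter, while a 1.4-fold higher number from compound 1 to compound 3 (0.15 log units; within the scatter) stays within it. Among the compounds with values here, no bromo compound has been measured. A small move towards a lower number is therefore expected in this assay, and the estimated change is a 1.6-fold lower number from compound 3 to compound 4 (0.19 log units; within the scatter) at most near the scatter. For compound 4 16000 nM is the estimated value, with 7500 nM to 32000 nM as the expected range.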

Compound 4, half-maximal inhibitory concentration: 1600 nM
Beside the measured number, compound 4's estimate is 10-fold (1.00 log units) above it; measured number below the stated range.
By their numbers in this assay, from the lowest: compound 4; then compounds 2, 1 and 3 (each within the scatter of the next, the first and the last beyond it).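

The 2-bromophenyl group on the carbonyl carbon gives a 16-fold lower number from compound 3 to compound 4 (1.19 log units; beyond the scatter) in this assay, showing that this position can support a much larger step than the earlier changes revealed. It also gives a 5.9-fold lower number from compound 2 to compound 4 (0.77 log units; beyond the scatter) and an 11-fold lower number from compound 1 to compound 4 (1.04 log units; beyond the scatter), which places compound 4 as the strongest of the four compounds. Nothing available here accounts for this gain.

The change alters the halogen and its place on the ring together, so the compounds shown do not separate the two. Going by these compounds, how an amine or a methoxy group on that phenyl ring would read remains open.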